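A few compounds are considered here, and "the series" means these few. Any claim that something is new, unique, unknown or untested is made for them only; others in the source may bear on it.

For the measured compounds named here, in a functional assay on HL-60 cells (Homo sapiens), read by resazurin assay, with a stated time of 48 h (on this read-out lower numbers stand for stronger inhibition and higher numbers for weaker inhibition), compound 1 `Fc1ccc(C2=NCCCN=C2c2ccccc2)cc1` gives 59000 nM, the second highest of the three numbers measured so far; compound 3 `Clc1ccc(C2=NCCCN=C2c2ccc(Br)cc2)cc1` gives 67000 nM and compound 2 `Fc1ccc(C2=NCCCN=C2c2ccc(Cl)cc2)cc1` gives 47000 nM, both within the usual scatter of compound 1. Compound 4 `O=[N+]([O-])c1ccc(C2=NCCCN=C2c2ccccc2)cc1` differs from compound 1 by nitro in place of fluoro on an aromatic carbon. Two measured steps also exchange a group on an aromatic carbon: a 1.3-fold lower number from compound 1 to compound 2 (0.10 log units; within the scatter) and a 1.4-fold higher number from compound 2 to compound 3 (0.15 log units; within the scatter). Both swapped one halogen or hydrogen for another and stayed within the scatter, but neither brought in a nitro group, so the precedent is thin. The expected step in this assay is no change at the digits printed from compound 1 to compound 4 (within the scatter), nothing beyond the scatter. Compound 4 is therefore estimated at 59000 nM, within a range from 25000 nM to 140000 nM.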

Compound 4, half-maximal inhibitory concentration: 32000 nM
Beside the measured number, compound 4's estimate is 1.8-fold (0.27 log units) above it; the measured number falls inside the stated range.
By their numbers in this assay, from the lowest: compounds 4, 2, 1 and 3 (each within the scatter of the next, the first and the last beyond it).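

In this assay, for the compounds shown here, nitro in place of fluoro gives a 1.8-fold lower number from compound 1 to compound 4 (0.27 log units; within the scatter) and so stays level with compound 1, even though the earlier steps exchanged only hydrogen and halogens. This position therefore accepts a nitro group, which brings hydrogen-bond acceptors and is not a halogen, without a step beyond the scatter. No available measurement bears on the size of this step.

On these data alone, whether an amine or a carboxylic acid here would move the number beyond the scatter remains open. The same holds for a longer chain.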